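Lengthening the ester chain: compound 3 to compound 4

The compounds below may be only part of what the source reports. "The series", "measured", "known", "first", "only" and "open" are said of these compounds alone.

Of the compounds shown here, three have so far been measured in an assay on membranes from CHO cells for displacement of a labelled ligand from adenosine receptor A1 (Homo sapiens), read by scintillation counting, with a stated time of 60 min, tested at 1 uM; a lower number here means less inhibition, a higher number more inhibition at the concentration tested (going by the name of the read-out). Compound 1 `CCCOC(=O)C1=C(C)N(C)C(=O)NC1c1ccoc1` gives 1%. Compound 2 `COC(=O)C1=C(C)N(C)C(=O)NC1c1ccsc1` gives 24%, and compound 3 `CCOC(=O)C1=C(C)N(C)C(=O)NC1c1ccsc1` gives 32%. Compound 3 carries the highest of the three numbers, but its nearest neighbour, compound 2, sits within the scatter, so no order between them is claimed; only compound 1 lies beyond the scatter below it. Compound 1 differs from compound 3 in two places, so its lower number cannot be assigned to either change alone.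

Compound 4 `CCCOC(=O)C1=C(C)N(C)C(=O)NC1c1ccsc1` has not yet been measured. Against compound 3 the change is methyl in place of hydrogen on a saturated chain carbon, two bonds along the chain from an oxygen next to a carbonyl group. Among the compounds with values here, the one measured step that bears on it is a number 8 percentage points higher from compound 2 to compound 3 (within the scatter), the same kind of change on the same chain, and it stayed within the scatter. On that basis the further step is expected to be small, no change at the digits printed from compound 3 to compound 4 (within the scatter), with no direction beyond the scatter. Compound 4 is therefore estimated at 32%, within 12% to 52%.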

Compound 4, a percentage reported as inhibition, at one concentration (the size of the read-out at that concentration, not a potency): 2%
Beside the measured number, compound 4's estimate is 30 percentage points above it; measured number below the stated range.
By their numbers in this assay, from the lowest: compounds 1 and 4 (each within the scatter of the next); then compounds 2 and 3 (each within the scatter of the next).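

In this assay, methyl in place of hydrogen gives a clear step at this position, two bonds along the chain from an oxygen next to a carbonyl group (a number 30 percentage points lower from compound 3 to compound 4 (beyond the scatter)), whereas the same kind of change on the carbon bound to that oxygen stayed within the scatter (a number 8 percentage points higher from compound 2 to compound 3 (within the scatter)). The whole change of ethyl in place of hydrogen on that carbon is also readable (a number 22 percentage points lower from compound 2 to compound 4 (beyond the scatter)), and with the propoxy chain held constant, thiophen-3-yl in place of furan-3-yl leaves no readable difference (a number 1 percentage points higher from compound 1 to compound 4 (within the scatter)), so the low number of compound 1 goes with the propoxy chain and not with the ring change. No measurement shown accounts for this sharp sensitivity to chain length.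

Going by these compounds, whether a longer chain or a branched isopropyl ester would stay this low remains open. Whether a terminal amine or carboxylic acid on the chain would restore the number is equally unresolved.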